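Replacing One Side Group on a Quiet Core

This account rests on a few compounds, and the source may have more. Where it says the series, first, only, none or still open, it means among the compounds named here.

Compound 1 `O=C(Nc1ccccc1Cl)Nc1nn(-c2ccccc2)c(=O)c2ccccc12` sits, in an assay on CHO cells for displacement of a labelled ligand from adenosine receptor A1 (Homo sapiens), tested at 10 uM (a lower number here means less inhibition, a higher number more inhibition at the concentration tested (going by the name of the read-out)), at 0%, level with compound 3 `COc1ccc(C(=O)Nc2nn(-c3ccccc3)c(=O)c3ccccc23)cc1` at 0%, and together these are the lowest of the three numbers. Compound 2 `O=C(Nc1ccc(Cl)cc1)Nc1nn(-c2ccccc2)c(=O)c2ccccc12`, the furthest, gives 10%, and the step of a number 10 percentage points higher from compound 1 to compound 2 (within the scatter) stays within the scatter. Compound 4 `O=C(Nc1nn(-c2ccccc2)c(=O)c2ccccc12)c1ccc(Cl)cc1` differs from compound 1 by 4-chlorophenyl in place of (2-chlorophenyl)amino on a carbonyl carbon. The measured step that bears most on this is no change at the digits printed from compound 1 to compound 3 (within the scatter), where a 4-methoxyphenyl took the place of (2-chlorophenyl)amino on the same carbonyl carbon. The step of a number 10 percentage points lower from compound 2 to compound 3 (within the scatter) likewise stays within the scatter. Among the compounds with values here, no measured step exceeds the scatter. The step expected for compound 4 is thus a number 2 percentage points higher from compound 1 to compound 4 (within the scatter), nothing beyond the scatter. Compound 4 is estimated at 2%, with a range from -10% to 15%.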

Compound 4, a percentage reported as inhibition, at one concentration (the size of the read-out at that concentration, not a potency): 26%
For compound 4 the middle estimate is 24 percentage points below the measured one; measured number above the stated range.
By their numbers in this assay, from the lowest: compounds 1, 3 and 2 (each within the scatter of the next); then compound 4.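

Within the data shown here, with 4-chlorophenyl on the carbonyl carbon, this assay moves beyond the scatter for the first time: replacing the two (chlorophenyl)amino groups gives a number 26 percentage points higher from compound 1 to compound 4 (beyond the scatter) and a number 16 percentage points higher from compound 2 to compound 4 (beyond the scatter). Chloro in place of methoxy on an aromatic carbon gives a number 26 percentage points higher from compound 3 to compound 4 (beyond the scatter), so at this place the substituent on the ring counts, and 4-methoxyphenyl did not foretell the result. No data at hand account for the rise.

On these data alone, whether a bromo or a trifluoromethyl in place of the chloro would keep the rise stays open. A single-concentration read-out also leaves the potency of compound 4 open.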